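From methoxy to fluoro at the same place

This account rests on a few compounds, and the source may have more. Where it says the series, first, only, none or still open, it means among the compounds named here.

In a functional assay on NCI-H460 cells (Homo sapiens) for inhibition, read by sulforhodamine B assay, with a stated time of 48 h, tested at 10 uM (a lower number here means less inhibition, a higher number more inhibition at the concentration tested (going by the name of the read-out)), compound 1 `COc1ccc(-c2cn3ccnc3c(-c3ccc4ncn(C5CCCCC5)c4c3)n2)cc1` gives 91.1%. Among the compounds with values here, compound 2 `COc1ccccc1-c1cn2ccnc2c(-c2ccc3ncn(C4CCCCC4)c3c2)n1` gives 9.62%, the lowest of the two numbers known. Within the data shown here, the only measured step, a number 81.5 percentage points lower from compound 1 to compound 2 (beyond the scatter), moves the methoxy group rather than exchanging it. Compound 3 `Fc1ccccc1-c1cn2ccnc2c(-c2ccc3ncn(C4CCCCC4)c3c2)n1` differs from compound 2 by fluoro in place of methoxy on an aromatic carbon. Among the measured compounds shown here, no measured step exchanges one group for another at the same place, so the low reading of compound 2 is the only anchor. The expected step is a number 5.4 percentage points higher from compound 2 to compound 3 (within the scatter), keeping the read-out low. The estimate for compound 3 is 15%, within 0% to 45%.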

Compound 3, a percentage reported as inhibition, at one concentration (the size of the read-out at that concentration, not a potency): 8.1%
Compound 3: middle estimate off by 6.9 percentage points, on the high side; the measured number falls inside the stated range.
By their numbers in this assay, from the lowest: compounds 3 and 2 (each within the scatter of the next); then compound 1.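

In this assay with fluoro in place of methoxy on the aromatic carbon ortho to a large group, the reading stays low (a number 1.5 percentage points lower from compound 2 to compound 3 (within the scatter)), so the low reading at this place is not tied to methoxy alone. Compound 3 also stands far from compound 1 (a number 83 percentage points lower from compound 1 to compound 3 (beyond the scatter)), but that step changes both the group and its place, so it cannot separate the two. Nothing available gives a cause for these readings.

Going by these compounds, whether fluoro would keep the high reading at the place methoxy holds in compound 1 stays open. So does whether an amine or a carboxylic acid ortho to a large group would read any differently.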